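The compounds below may be only part of what the source reports. "The series", "measured", "known", "first", "only" and "open" are said of these compounds alone.

The compounds measured in a functional assay on M21 cells (Homo sapiens) for cytotoxicity, read by sulforhodamine B assay, with a stated time of 48 h (a lower number here means a stronger inhibitor, a higher number a weaker inhibitor), are these:

compound 1, `Cc1ccccc1OS(=O)(=O)c1ccc(NC(=O)NCCCCl)cc1`, giving 25000 nM
compound 2, `CCc1ccccc1OS(=O)(=O)c1ccc(NC(=O)NCCCCl)cc1`, giving 15000 nM
compound 3, `CCc1ccccc1NS(=O)(=O)c1ccc(NC(=O)NCCCCl)cc1`, giving only a limit of the assay, > 200000 nM

Compound 4, `CCCc1ccccc1NS(=O)(=O)c1ccc(NC(=O)NCCCCl)cc1`, has not yet been measured in this assay. Compound 3 and compound 1 are built on different cores, and the difference between the two cores is not broken down here.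

One change occurs twice among these four compounds. From compound 1 to compound 2 it is methyl in place of hydrogen on a saturated chain carbon bound to an aromatic carbon, and this assay shows a 1.7-fold lower number from compound 1 to compound 2 (0.22 log units; within the scatter). From compound 3 to compound 4 the change is methyl in place of hydrogen on a saturated chain carbon, two bonds along the chain from an aromatic carbon. This is the same kind of change, not the same one: in the first case the methyl enters on a saturated chain carbon bound to an aromatic carbon, in the second on a saturated chain carbon two bonds along the chain from an aromatic carbon.

For the measured compounds named here, the step from compound 1 to compound 2 lay within the scatter, so a small step is the only precedent. Compound 3 sits at the limit of > 200000 nM in this assay, at which 1 of the 3 values shown sits, and a step of that size is not expected to move compound 4 away from it. The expected step from compound 3 to compound 4 in this assay is therefore estimated as a number no higher from compound 3 to compound 4 (the limit leaves the size open). Compound 4 is expected to give about 200000 nM in this assay, somewhere between 80000 nM and 500000 nM, most likely reported again only as a limit.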

Compound 4, half-maximal inhibitory concentration: 38000 nM
Compound 4: the middle estimate sits 5.3-fold (0.72 log units) above what was measured; the measured number lies below the stated range.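

In this assay the change gives an at least 5.2-fold lower number from compound 3 to compound 4 (0.72 log units; beyond the scatter), so its effect is not the same size on the two cores: the same change on two cores in this assay, a 1.7-fold lower number (0.22 log units; within the scatter) from compound 1 to compound 2 and an at least 5.2-fold lower number (0.72 log units; beyond the scatter) from compound 3 to compound 4, at least 3.1-fold (0.49 log units) apart, beyond the scatter of two such steps. From the compounds shown here alone, compound 3 gives > 200000 nM, which is a limit of the assay and not a number, so the step from it has only a lower bound and its true size stays open: the limit of > 200000 nM in this assay, at which 1 of the 4 values shown sits. The comparison does not show why the two steps differ, since the cores differ and the methyl also enters at a different place, on a saturated chain carbon bound to an aromatic carbon in the first case and on a saturated chain carbon two bonds along the chain from an aromatic carbon in the second, and one pair on each core cannot separate these two differences.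

The compounds shown leave open whether the 2-ethylphenyl to 2-propylphenyl change would give a similar step on the core of compound 1, and whether a butyl chain would lower the number further on either core. They also leave open what an amine or a carboxylic acid at the end of that chain would give in this assay.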